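Coumarin-type series: oxygen side chain swap at compound 2

A few compounds are considered here, and "the series" means these few. Any claim that something is new, unique, unknown or untested is made for them only; others in the source may bear on it.

Measured compounds and their numbers in an assay on isolated protein (strain Sprague-Dawley) for inhibition of Amine oxidase [flavin-containing] B (Rattus norvegicus), read by spectrophotometry, with a stated time of 5 min; on this read-out lower numbers stand for stronger inhibition and higher numbers for weaker inhibition:
compound 1 `CCCOc1cc(=O)oc2cc(OCc3cccc(F)c3)ccc12`: 407 nM
compound 2 `CC(=O)COc1cc(=O)oc2cc(OCc3cccc(Cl)c3)ccc12`: 26.9 nM
compound 3 `NC(=O)COc1cc(=O)oc2cc(OCc3cccc(Br)c3)ccc12`: 8.91 nM

Compound 2 stands second highest of the three numbers in this assay. Its nearest neighbour is compound 3, which gives a lower number, and the gap lies beyond the scatter. Compound 1 gives the highest number, also beyond the scatter from compound 2. Among the measured compounds shown here, no single-point step between the measured compounds is available, so the three values can only be read side by side.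

Compound 4 `O=c1cc(Oc2ccccc2)c2ccc(OCc3cccc(Cl)c3)cc2o1` is not yet measured. The change from compound 2 is phenyl in place of 2-oxopropyl on an oxygen on an aromatic ring.

Of the measured compounds, compound 1 carries a plain propyl chain on the same oxygen and gives 407 nM, the weakest number here, whereas compound 3, with a chain carrying an amide, gives 8.91 nM. Compound 4 loses the acceptor of the 2-oxopropyl chain and takes an aromatic ring instead; for compound 4 the expected step in this assay is therefore a 5.6-fold higher number from compound 2 to compound 4 (0.75 log units; beyond the scatter), towards a higher number and beyond the scatter. Compound 4 is expected to give about 150 nM, within 30 nM to 800 nM.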

Compound 4, half-maximal inhibitory concentration: 4070 nM
Compound 4: the middle estimate sits 27-fold (1.43 log units) below what was measured, outside the stated range (above it).
By their numbers in this assay, from the lowest: compound 3; then compound 2; then compound 1; then compound 4.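

In this assay, among the compounds shown here, phenyl in place of 2-oxopropyl on this oxygen gives a 150-fold higher number from compound 2 to compound 4 (2.18 log units; beyond the scatter) and is the first change confined to one place. The result shows that this oxygen substituent can by itself move the number by a large margin, at least with the rest of compound 2 held fixed. Nothing shown accounts for the step, which cannot be assigned to the loss of the carbonyl, the loss of the chain or the arrival of the aromatic ring.

As far as these compounds go, whether the ring itself or its direct attachment to the oxygen matters remains open, and a benzyl group on the same oxygen would separate the two. Also open, from the compounds shown here alone, is how a longer chain, or one ending in an amine or a carboxylic acid, would compare with the 2-oxopropyl of compound 2 on an otherwise unchanged structure.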